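A few compounds are considered here, and "the series" means these few. Any claim that something is new, unique, unknown or untested is made for them only; others in the source may bear on it.

Compound 3 `ClCc1ccc(Cn2cnc3c(Cl)nc(Cl)nc32)cc1` and compound 1 `Nc1nc(Cl)c2ncn(Cc3ccc(CCl)cc3)c2n1` differ in a single place: amino in place of chloro on an aromatic carbon. In a functional assay on COLO 205 cells (Homo sapiens) for cytotoxicity, read by sulforhodamine B assay, with a stated time of 48 h (a lower number here means that less compound is tolerated, a higher number that more compound is tolerated), compound 1 gives 42700 nM. For compound 3 this assay reports only a limit, > 100000 nM. The step between them is an at least 2.3-fold lower number from compound 3 to compound 1 (0.36 log units; beyond the scatter), and it can be stated only as a bound because of the limit of > 100000 nM in this assay, at which 2 of the 3 values shown sit. Compound 2 `ClCc1cccc(Cn2cnc3c(Cl)nc(Cl)nc32)c1` is built from the same atoms as compound 3, joined differently; the difference between the two cores is not broken down here. For compound 2 this assay likewise reports only a limit, > 100000 nM. Compound 4 `Nc1nc(Cl)c2ncn(Cc3cccc(CCl)c3)c2n1` stands to compound 2 as compound 1 stands to compound 3, carrying the same change at the same place: amino in place of chloro on an aromatic carbon. For the measured compounds named here, the step seen from compound 3 to compound 1, an at least 2.3-fold lower number from compound 3 to compound 1 (0.36 log units; beyond the scatter), is the only guide to what this change does here. On that basis the expected step is an at least 2.0-fold lower number from compound 2 to compound 4 (0.30 log units; that floor lies within the scatter). Because compound 2 sits at a limit, > 100000 nM, the result for compound 4 may again be a limit. Compound 4 is accordingly expected to give about 50000 nM, somewhere between 25000 nM and 100000 nM.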

Compound 4, concentration lethal to 50% of the cells: 97700 nM
For compound 4 the middle estimate is 2.0-fold (0.29 log units) below the measured one, and the stated range covers the measured number.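

Carried to the other core, amino in place of chloro on an aromatic carbon gives an at least 1.0-fold lower number from compound 2 to compound 4 (0.01 log units; that floor lies within the scatter) in this assay, a floor and not a measured size. For compound 2 the figure of > 100000 nM is a limit of the assay and not a number. In both pairs the amino compound gives a measured number and its chloro partner only a limit, but this does not show that the change has the same size on the two cores: the same change on two cores in this assay, an at least 2.3-fold lower number (0.36 log units; beyond the scatter) from compound 3 to compound 1 and an at least 1.0-fold lower number (0.01 log units; that floor lies within the scatter) from compound 2 to compound 4; the limit leaves it open whether they differ.

Going by these compounds, the true size of each step stays open, and so does any gap between them: the limit of > 100000 nM in this assay, at which 2 of the 4 values shown sit. The compounds shown also leave open what other groups would do on the aromatic carbon between two ring nitrogen atoms, such as a methylamino group, a hydroxyl group or a methoxy group.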